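The source may hold more compounds than are shown below. What is called first, only, known or untested is meant among the compounds shown, and "the series" means these compounds.

Measured so far in a functional assay on PANC-1 cells (Homo sapiens) for antiproliferative activity, read by MTT assay, with a stated time of 48 h; on this read-out lower numbers stand for stronger inhibition and higher numbers for weaker inhibition: compound 1 `Cc1c(C(=O)OCCCN(C)C)oc2ccc(N(Cc3ccc(Br)cc3)S(=O)(=O)c3ccc(Br)cc3)cc12` gives 24600 nM; compound 2 `Cc1c(C(=O)NCC(O)CO)oc2ccc(N(Cc3ccc(Br)cc3)S(=O)(=O)c3ccc(Br)cc3)cc12` gives 29300 nM.

Among the measured compounds shown here, compound 2 holds the higher of the two numbers, but its only neighbour is compound 1, and the step of a 1.2-fold higher number from compound 1 to compound 2 (0.08 log units; within the scatter) lies within the scatter. Compound 3 `Cc1c(C(=O)NCCNc2ccccc2)oc2ccc(N(Cc3ccc(Br)cc3)S(=O)(=O)c3ccc(Br)cc3)cc12` carries the change (anilinomethyl in place of 1,2-dihydroxyethyl on a saturated chain carbon bound to an amide-type nitrogen). For the measured compounds named here, the one measured step also alters the group on the carbonyl carbon and produced no shift beyond the scatter, so no strong movement is expected in this assay. Compound 3 is therefore estimated at 24000 nM, between 9000 nM and 60000 nM, a step of a 1.2-fold lower number from compound 2 to compound 3 (0.09 log units; within the scatter).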

Compound 3, half-maximal inhibitory concentration: > 40000 nM
Compound 3 was reported as a limit (the forecaster's own chance of this, stated with the estimate: 10%); middle value at least 1.6-fold (0.22 log units) away from the limit.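

In this assay compound 3 is reported only as a limit, not as a number: > 40000 nM. Anilinomethyl in place of 1,2-dihydroxyethyl gives an at least 1.3-fold higher number from compound 2 to compound 3 (0.13 log units; that floor lies within the scatter), and (2-anilinoethyl)amino in place of 3-(dimethylamino)propoxy gives an at least 1.6-fold higher number from compound 1 to compound 3 (0.21 log units; that floor lies within the scatter); both floors lie within the scatter, so neither step establishes a real loss. Still, the six-membered aromatic ring brought in by this change produced no lower number. On these data alone, how far the true value of compound 3 lies past its limit stays open, as does whether a carboxylic acid or a longer chain ending in a primary amine would shift the number beyond the scatter.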